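Spiro Quinoxaline Analogues on Endothelial Cells: a Third Member

A few compounds are considered here, and "the series" means these few. Any claim that something is new, unique, unknown or untested is made for them only; others in the source may bear on it.

Compound 1 `N#CC1=C(N)Oc2c(c3nc4ccccc4nc3c3ccccc23)C12C(=O)N(Cc1cnnn1-c1ccc(F)c(Cl)c1)c1ccccc12`: > 50000 nM
Compound 2 `CCOc1ccc(-n2nncc2CN2C(=O)C3(C(C#N)=C(N)Oc4c(N)cc5nc6ccccc6nc5c43)c3ccccc32)cc1`: > 50000 nM

In an ADME assay on HUVEC cells (Homo sapiens) for antiproliferative activity, read by MTT assay, with a stated time of 48 h (a lower number here means a stronger inhibitor, a higher number a weaker inhibitor), compound 1 gives > 50000 nM, which is a limit of the assay. In this assay compound 2 gives > 50000 nM, again only a limit. Compound 2 thus stands where both values shown sit (the limit of > 50000 nM in this assay, at which 2 of the 2 values shown sit), with no number to compare. Compound 3 `N#CC1=C(N)Oc2c(N)cc3nc4ccccc4nc3c2C12C(=O)N(Cc1cnnn1-c1ccc(F)c(Cl)c1)c1ccccc12` carries 3-chloro-4-fluorophenyl in place of 4-ethoxyphenyl on an aromatic nitrogen. For the measured compounds named here, no measured step exists, and compound 1 already bears the entering group; no step beyond the scatter is expected in this assay, and a limit seems the likely outcome. Compound 3 is estimated at 60000 nM (20000 nM to 200000 nM). That estimate implies a step that the limit leaves unreadable from compound 2 to compound 3.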

Compound 3, half-maximal inhibitory concentration: > 50000 nM
Compound 3: no number, only a limit; the forecaster's own chance of this, stated with the estimate: 85%; the middle value lies beyond the limit too.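

In this assay, for the compounds shown here, compound 3 gives > 50000 nM as a limit, so no step from compound 2 to compound 3 can be read. Compound 1, compound 2 and compound 3 leave open what number any of them would reach in this assay under these conditions.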